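Compound 4, a Dimethoxyphenyl Amide Beside Compound 2

This account rests on a few compounds, and the source may have more. Where it says the series, first, only, none or still open, it means among the compounds named here.

This series shares a core carrying a 4-fluorophenyl group and an amide-linked aryl arm that is varied. In a functional assay on GTL 16 cells for antiproliferative activity against GTL 16 cell line (Homo sapiens), read by CCK-8 assay, with a stated time of 72 h (a higher number here means a weaker inhibitor, a lower number a stronger inhibitor), compound 1 `O=C(Nc1cccc(-c2oc3cc(-c4ccc(F)cc4)ccc3c(=O)c2O)c1)c1ccc(F)cc1` gives 14600 nM. Compound 2 `Cc1ccc(C(=O)Nc2cccc(-c3oc4cc(-c5ccc(F)cc5)ccc4c(=O)c3O)c2)cc1` gives 12900 nM in this assay, and compound 3 `COc1ccc(C(=O)Nc2cccc(-c3oc4cc(-c5ccc(F)cc5)ccc4c(=O)c3O)c2)c(F)c1` gives 15300 nM. Compound 2 holds the lowest of the three numbers, but its neighbours are close: a 1.1-fold lower number from compound 1 to compound 2 (0.05 log units; within the scatter) and a 1.2-fold higher number from compound 2 to compound 3 (0.07 log units; within the scatter), and likewise a 1.0-fold higher number from compound 1 to compound 3 (0.02 log units; within the scatter). All three changes at the aryl arm therefore left this assay essentially unchanged.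

Compound 4 `COc1cc(OC)cc(C(=O)Nc2cccc(-c3oc4cc(-c5ccc(F)cc5)ccc4c(=O)c3O)c2)c1` is reached from compound 2 by the change (3,5-dimethoxyphenyl in place of 4-methylphenyl on a carbonyl carbon). Among the measured compounds shown here, the steps that bear on it are those at the same carbonyl carbon, from compound 1 to compound 3 and from compound 2 to compound 3, each within the scatter, so compound 4 is expected to show no step beyond the scatter, a 1.1-fold higher number from compound 2 to compound 4 (0.04 log units; within the scatter). Compound 4 is estimated at 14000 nM in this assay, with a range from 7000 nM to 28000 nM.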

Compound 4, half-maximal inhibitory concentration: 19600 nM
The estimate for compound 4 lay 1.4-fold (0.15 log units) below the measured number; measured number inside the range.
By their numbers in this assay, from the lowest: compounds 2, 1, 3 and 4 (each within the scatter of the next).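

The 3,5-dimethoxyphenyl group brings oxygen atoms and hydrogen-bond acceptors that 4-methylphenyl lacks, yet in this assay this change at the carbonyl carbon gives a 1.5-fold higher number from compound 2 to compound 4 (0.18 log units; within the scatter). Set against the other two aryl arms, the same group gives a 1.3-fold higher number from compound 3 to compound 4 (0.11 log units; within the scatter) and a 1.3-fold higher number from compound 1 to compound 4 (0.13 log units; within the scatter), so this position has now tolerated a dimethoxy-substituted arm as well, with no step beyond the scatter. No measurement here offers an explanation for this flat response.

The compounds shown leave open whether an aryl arm carrying an amine or a carboxylic acid at this carbonyl carbon would move the number beyond the scatter. As far as these compounds go, all four compounds also keep the 4-fluorophenyl group on the shared core, so what a change at that group would do remains unknown.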